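The source may report more compounds than this note shows. Statements on the series, on what has been measured and on what is new or still open speak of the compounds shown alone.

Working notes on the series, read in a functional assay on PC-3 cells (Homo sapiens) for antiproliferative activity, read by WST assay, with a stated time of 3 days; on this read-out lower numbers stand for stronger inhibition and higher numbers for weaker inhibition. Compound 1 `CCCCOc1c(-c2cc(OC)c(OC)c(OC)c2)oc2ccccc2c1=O` gives 12800 nM. For the measured compounds named here, compound 2 `CCCN(CCC)CCCCCOc1c(-c2cc(OC)c(OC)c(OC)c2)oc2ccccc2c1=O` gives 2600 nM, the lower of the two numbers so far.

Compound 3 `CCCCN(CCCC)CCCCOc1c(-c2cc(OC)c(OC)c(OC)c2)oc2ccccc2c1=O` has not yet been measured. Its difference from compound 2 is dibutylamino in place of (dipropylamino)methyl on a saturated chain carbon, four bonds along the chain from an oxygen on an aromatic ring. Cut one bond further out, the same difference reads 4-(dipropylamino)butyl to 3-(dibutylamino)propyl.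

Going by the values given here, only one measured step bears on this change: a 4.9-fold lower number from compound 1 to compound 2 (0.69 log units; beyond the scatter), a modest step that brings in (dipropylamino)methyl in place of hydrogen at the same place. Among the compounds with values here, no measured pair exchanges one amino-bearing group for another, so the size of such an exchange has not been observed directly. With an amino-bearing group kept at this place, no step beyond the scatter is expected in this assay. The expected step is a 1.1-fold lower number from compound 2 to compound 3 (0.03 log units; within the scatter). For compound 3 the estimated value is 2400 nM, with an expected range of 1100 nM to 5500 nM.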

Compound 3, half-maximal inhibitory concentration: 5300 nM
The estimate for compound 3 lay 2.2-fold (0.34 log units) below the measured number; measured number inside the range.
By their numbers in this assay, from the lowest: compound 2; then compound 3; then compound 1.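

In this assay, the exchange of one amino-bearing group for another on a saturated chain carbon, four bonds along the chain from an oxygen on an aromatic ring, gives a 2.0-fold higher number from compound 2 to compound 3 (0.31 log units; beyond the scatter), so the choice between (dipropylamino)methyl and dibutylamino at this place registers in the read-out, though only as a modest step. The gain over the hydrogen of compound 1 is also not tied to (dipropylamino)methyl alone, since dibutylamino at the same place gives a 2.4-fold lower number from compound 1 to compound 3 (0.38 log units; beyond the scatter), and both amino-bearing compounds therefore read lower than compound 1. Nothing available explains the difference between these two groups.

The exchange alters the chain leading to the nitrogen and the alkyl groups on the nitrogen together, so the compounds shown do not separate the contribution of the chain from that of the substituents on the nitrogen. Also open, from the compounds shown here alone, is how a smaller dimethylamino group, a ring amine such as piperidine, or a non-basic group such as an amide would read at this place on the shared core.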